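This account rests on a few compounds, and the source may have more. Where it says the series, first, only, none or still open, it means among the compounds named here.

Measured so far:
compound 1, `O=C(Nc1ccc(F)cc1C(F)(F)F)c1cc(Cl)ccc1O`: 13000 nM
compound 2, `O=C(Nc1ccc(Br)cc1C(F)(F)F)c1cc(Cl)ccc1O`: 11000 nM
compound 3, `O=C(Nc1ccc(F)c(C(F)(F)F)c1)c1cc(Cl)ccc1O`: 5300 nM

The three compounds were tested in an ADME assay on cells (Macrophage, Mus musculus) for cytotoxicity, read by resazurin assay, with a stated time of 3 days; a higher number here means a weaker inhibitor, a lower number a stronger inhibitor. In this assay compound 1 gives 13000 nM, and compound 2 gives 11000 nM. Within the data shown here, the only counted step between them is bromo in place of fluoro on an aromatic carbon, which made a 1.2-fold lower number from compound 1 to compound 2 (0.07 log units; within the scatter). Compound 3 gives 5300 nM, the lowest of the three numbers; its two values against compounds 1 and 2 show it beyond the scatter on either side. How the core of compound 3 differs from the core of compound 1 is not broken down here.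

Compound 4, `O=C(Nc1ccc(Br)c(C(F)(F)F)c1)c1cc(Cl)ccc1O`, has not yet been measured in this assay. It differs from compound 3 by bromo in place of fluoro on an aromatic carbon. This is the same kind of change as that from compound 1 to compound 2, but not the same: in compound 2 the bromo sits meta to a trifluoromethyl group, whereas in compound 4 it sits ortho to a trifluoromethyl group, para to a large group in both cases. Because the earlier step was a 1.2-fold lower number from compound 1 to compound 2 (0.07 log units; within the scatter), a step of similar size is expected here, with some extra room for the different surroundings. The step from compound 3 to compound 4 that this estimate means is expected to be a 1.2-fold lower number from compound 3 to compound 4 (0.07 log units; within the scatter). Compound 4 is therefore expected to give about 4500 nM in this assay, estimated to fall between 2000 nM and 10000 nM.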

Compound 4, half-maximal inhibitory concentration: 4500 nM
The estimate for compound 4 equals the measured number at the digits printed; low and high end bracket the measured number.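

In this assay, bromo in place of fluoro on an aromatic carbon gave a 1.2-fold lower number from compound 3 to compound 4 (0.07 log units; within the scatter), so on this second core the exchange again leaves the read-out essentially where it was. Set beside the earlier step, the two cores agree: the same change on two cores in this assay, a 1.2-fold lower number (0.07 log units; within the scatter) from compound 1 to compound 2 and a 1.2-fold lower number (0.07 log units; within the scatter) from compound 3 to compound 4, 1.0-fold (0.00 log units) apart, within the scatter of two such steps. Among these compounds, this shows that, across these two pairs, the change carries from one core to the other without a detectable difference, including where the bromo sits ortho to a trifluoromethyl group in compound 4, but it rests on only two pairs whose steps are too small to assign the exchange a fixed size, and it says nothing about other cores or other assays.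

The compounds shown keep the chloro, the hydroxyl and the amide in place and carry only fluoro or bromo at the changing site, so it remains open whether another group there, such as an amine, a carboxylic acid or a longer chain, would shift the number in this assay. Also open, from the compounds shown here alone, is whether the quiet behaviour of this exchange would hold if the chloro or the hydroxyl were replaced.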